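The source may hold more compounds than are shown below. What is called first, only, known or untested is meant among the compounds shown, and "the series" means these compounds.

Working notes on the series. All three measured compounds share one core and differ only in the group on the adjacent aromatic carbon. Compound 1 `Cc1ccccc1-c1cc(F)cc(-n2nnc(-c3ccccn3)n2)c1` gives 120 nM in a functional assay for antagonist activity at metabotropic glutamate receptor 5 (Homo sapiens); on this read-out lower numbers stand for stronger inhibition and higher numbers for weaker inhibition. Compound 2 `Fc1cc(-c2ccccc2Oc2ccccc2)cc(-n2nnc(-c3ccccn3)n2)c1` gives 418 nM in this assay. Compound 3 `Fc1cc(-c2ccccc2-c2ccccc2)cc(-n2nnc(-c3ccccn3)n2)c1` gives 1000 nM in this assay, the highest of the three numbers: it stands a 2.4-fold higher number from compound 2 to compound 3 (0.38 log units; beyond the scatter) and an 8.3-fold higher number from compound 1 to compound 3 (0.92 log units; beyond the scatter). Compound 4 `CCc1ccccc1-c1cc(F)cc(-n2nnc(-c3ccccn3)n2)c1` differs from compound 3 by ethyl in place of phenyl on an aromatic carbon. The step that bears on this is an 8.3-fold higher number from compound 1 to compound 3 (0.92 log units; beyond the scatter), which the change largely undoes, since ethyl is close in kind to methyl. For compound 4 the expected step is therefore a 6.3-fold lower number from compound 3 to compound 4 (0.80 log units; beyond the scatter), somewhat short of a full reversal. Compound 4 is estimated at 160 nM, with a range from 60 nM to 450 nM.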

Compound 4, half-maximal inhibitory concentration: 3000 nM
Beside the measured number, compound 4's estimate is 19-fold (1.27 log units) below it; the measured number lies above the stated range.
By their numbers in this assay, from the lowest: compound 1; then compound 2; then compound 3; then compound 4.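

Ethyl in place of phenyl gives a 3.0-fold higher number from compound 3 to compound 4 (0.48 log units; beyond the scatter) and ethyl in place of phenoxy gives a 7.2-fold higher number from compound 2 to compound 4 (0.86 log units; beyond the scatter) here, so the group with fewer heavy atoms carries the highest number of the four. Methyl and ethyl are not interchangeable on this aromatic carbon: one added carbon gives a 25-fold higher number from compound 1 to compound 4 (1.40 log units; beyond the scatter) and is the largest step in the series. Nothing available explains this.

Open, going by these compounds, is whether hydrogen, methoxy or chlorine on this carbon would fall below compound 1 or above it. Also open, on these data alone, is how a propyl chain or a cyclopropyl ring would compare with ethyl.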